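Returning from the pyrazole ester to a chlorinated phenyl amine

The source may report more compounds than this note shows. Statements on the series, on what has been measured and on what is new or still open speak of the compounds shown alone.

For the measured compounds named here, compound 3 `COC(=O)Cn1cc(Nc2ncnc3ccc(-c4cnc(OC)c(NS(=O)(=O)c5ccc(F)cc5F)c4)cc23)cn1` gives 670 nM in a functional assay on MCF7 cells (Homo sapiens) for antiproliferative activity, read by sulforhodamine B assay, with a stated time of 72 h (on this read-out lower numbers stand for stronger inhibition and higher numbers for weaker inhibition), the lowest number of the three measured so far, although compound 2 `COc1ncc(-c2ccc3ncnc(Nc4cnn(CC(=O)O)c4)c3c2)cc1NS(=O)(=O)c1ccc(F)cc1F` sits within the scatter of it: compound 2 gives 700 nM, and the step of a 1.0-fold lower number from compound 2 to compound 3 (0.02 log units; within the scatter) is within the scatter. Compound 1 `COc1ncc(-c2ccc3ncnc(Nc4ccc(OCCO)cc4)c3c2)cc1NS(=O)(=O)c1ccc(F)cc1F` is the furthest away, giving 1650 nM, and the step of a 2.5-fold lower number from compound 1 to compound 3 (0.39 log units; beyond the scatter) lies beyond the scatter.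

Compound 4 `COc1ncc(-c2ccc3ncnc(Nc4ccc(OCCO)c(Cl)c4)c3c2)cc1NS(=O)(=O)c1ccc(F)cc1F` has not yet been measured. It differs from compound 3 in one place: 3-chloro-4-(2-hydroxyethoxy)phenyl in place of 1-((methoxycarbonyl)methyl)-1H-pyrazol-4-yl on a nitrogen on an aromatic ring. Going by the values given here, two measured steps bear on this change, both running the other way: a 2.4-fold lower number from compound 1 to compound 2 (0.37 log units; beyond the scatter) and a 2.5-fold lower number from compound 1 to compound 3 (0.39 log units; beyond the scatter). Each replaced the 4-(2-hydroxyethoxy)phenyl group with a substituted pyrazole and each lowered the number modestly. Going back from the pyrazole ester to a phenyl ring carrying the 2-hydroxyethoxy group should therefore undo that gain. Among the compounds with values here, no measured compound carries the chlorine, so its contribution cannot be read from the numbers in hand. Compound 4 is expected to give 1500 nM, within a range of 500 nM to 4500 nM, a number close to that of compound 1. The step this implies, a 2.2-fold higher number from compound 3 to compound 4 (0.35 log units; beyond the scatter), is expected to be modest and upward.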

Compound 4, half-maximal inhibitory concentration: 3740 nM
Compound 4: middle estimate off by 2.5-fold (0.40 log units), on the low side; the measured number falls inside the stated range.
By their numbers in this assay, from the lowest: compounds 3 and 2 (each within the scatter of the next); then compound 1; then compound 4.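

For the compounds shown here, the chloro in place of hydrogen on an aromatic carbon gives a 2.3-fold higher number from compound 1 to compound 4 (0.36 log units; beyond the scatter) in this assay and is the first measured read on a substituent added to the 4-(2-hydroxyethoxy)phenyl group; in this one pair, it moves the number up. With the chlorine present, 3-chloro-4-(2-hydroxyethoxy)phenyl on the nitrogen gives a 5.6-fold higher number from compound 3 to compound 4 (0.75 log units; beyond the scatter) against the methyl ester pyrazole and a 5.3-fold higher number from compound 2 to compound 4 (0.73 log units; beyond the scatter) against 1-(carboxymethyl)-1H-pyrazol-4-yl, so both pyrazoles stand further from compound 4 than from compound 1. The compounds shown come with no independent measurement that accounts for the chlorine step or for the difference between the phenyl and pyrazole groups.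

From the compounds shown here alone, whether fluoro, methyl or methoxy in place of the chloro would move the number in the same way remains open. So does the part played by the 2-hydroxyethoxy chain itself, which a longer chain, a 2-aminoethoxy chain or a carboxylic acid on the chlorinated phenyl ring would help to separate from the effect of the chlorine.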